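The compounds below may be only part of what the source reports. "The series", "measured", "known", "first", "only" and "open" are said of these compounds alone.

In a functional assay on DU-145 cells (Homo sapiens) for inhibition, read by trypan blue exclusion, with a stated time of 96 h (a higher number here means a weaker inhibitor of growth, a lower number a stronger inhibitor of growth), compound 1 `O=C(/C(=C\c1ccc(OCc2ccccc2)cc1)SCc1ccc(Cl)cc1)c1ccc(Cl)cc1` gives 1000 nM, and it stands level, at the digits shown, with compound 3 `O=C(/C(=C\c1ccc(OCc2ccccc2)cc1)S(=O)(=O)Cc1ccc(Cl)cc1)c1ccc(Cl)cc1`, which gives 1000 nM in this assay. Among the measured compounds shown here, the one measured step, no change at the digits printed from compound 1 to compound 3 (within the scatter), left the reading unchanged within the scatter. Compound 2 `O=C(O)c1ccc(C(=O)/C(=C\c2ccc(Br)c([N+](=O)[O-])c2)SCc2ccc(Cl)cc2)cc1` gives < 1000 nM in this assay, and that reading is a limit rather than a number. Compound 4 `O=C(/C(=C\c1ccc(O)cc1)SCc1ccc(Cl)cc1)c1ccc(Cl)cc1` differs from compound 1 by hydrogen in place of benzyl on an oxygen on an aromatic ring. For the measured compounds named here, no measured step touches that oxygen, so the only guide is the flat step from compound 1 to compound 3, and no movement beyond the scatter is expected in this assay. Compound 4 is therefore estimated at 1000 nM, between 300 nM and 3000 nM, an expected step of no change at the digits printed from compound 1 to compound 4 (within the scatter).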

Compound 4, concentration for 50% growth inhibition: 10000 nM
Compound 4: middle estimate off by 10-fold (1.00 log units), on the low side; measured number outside the range, above it.
By their numbers in this assay, from the lowest: compounds 1 and 3 (each within the scatter of the next); then compound 4.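

In this assay, the change from benzyloxy to hydroxy gives a 10-fold higher number from compound 1 to compound 4 (1.00 log units; beyond the scatter) and so weakens growth inhibition. This makes the oxygen on the aromatic ring the first place in the series where a single change moves the reading beyond the scatter, unlike the flat sulfanyl to sulfonyl step. Nothing shown gives a cause for this loss.

From the compounds shown here alone, whether a smaller ether such as methoxy, or a longer chain on that oxygen, would hold the reading stays open. So does whether an amine in place of that oxygen would do so.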